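The compounds below may be only part of what the source reports. "The series", "measured", "known", "first", "only" and "open" are said of these compounds alone.

Measured values in a functional assay on BT-549 cells (Homo sapiens) for inhibition, read by sulforhodamine B assay, with a stated time of 48 h (on this read-out lower numbers stand for stronger inhibition of growth and higher numbers for weaker inhibition of growth), are as follows:

Compound 1 (`COc1cc(-c2nn(-c3cccc(NC(=O)Nc4ccc(Cl)c(Cl)c4)c3)cc2-c2ccncc2)ccc1Cl`): 1680 nM
Compound 2 (`COc1cc(-c2nn(-c3cccc(NC(=O)Nc4cccc(C(F)(F)F)c4)c3)cc2-c2ccncc2)ccc1Cl`): 1250 nM
Compound 3 (`COc1cc(-c2nn(-c3cccc(NC(=O)c4ccc(Cl)c(C(F)(F)F)c4)c3)cc2-c2ccncc2)ccc1Cl`): 7540 nM

Compound 3 has the highest number of the three, and its gaps to the other two lie beyond the scatter (a 4.5-fold higher number from compound 1 to compound 3 (0.65 log units; beyond the scatter); a 6.0-fold higher number from compound 2 to compound 3 (0.78 log units; beyond the scatter)). Compound 4 (`COc1cc(-c2nn(-c3cccc(NC(=O)c4ccccc4)c3)cc2-c2ccncc2)ccc1Cl`) differs from it as follows (phenyl in place of 4-chloro-3-(trifluoromethyl)phenyl on a carbonyl carbon), with phenyl in place of 4-chloro-3-(trifluoromethyl)phenyl on a carbonyl carbon. For the measured compounds named here, no measured step makes this exact change. The nearest parallel is an exchange of one aromatic group for another, and that step stayed within the scatter (a 1.3-fold lower number from compound 1 to compound 2 (0.13 log units; within the scatter)). The two steps to compound 3 also alter the link, so they bear on it less. Little change is therefore expected in this assay, with at most a slight rise. The expected step is small (a 1.2-fold higher number from compound 3 to compound 4 (0.08 log units; within the scatter)). Compound 4 is estimated at 9000 nM as a middle value, with an expected range (3000 nM to 25000 nM).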

Compound 4, concentration for 50% growth inhibition: 1330 nM
Estimate against measurement, compound 4: 6.8-fold (0.83 log units) above; measured number below the stated range.
By their numbers in this assay, from the lowest: compounds 2, 4 and 1 (each within the scatter of the next); then compound 3.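

For the compounds shown here, on this carbonyl carbon, the change to plain phenyl in this assay gives a 5.7-fold lower number from compound 3 to compound 4 (0.75 log units; beyond the scatter) and so separates the aryl group from the link, which the earlier steps to compound 3 had changed together. The high number of compound 3 therefore does not follow from the amide link alone, as phenyl on the carbonyl carbon gives a 1.1-fold higher number from compound 2 to compound 4 (0.03 log units; within the scatter) and also a 1.3-fold lower number from compound 1 to compound 4 (0.10 log units; within the scatter) within the scatter. Substitution on that ring, not the loss of the arylamino nitrogen, separates compound 3 from the other three.

From the compounds shown here alone, whether the chlorine or the trifluoromethyl carries the step stays open, as does the outcome with an amine or a carboxylic acid on that phenyl. No available evidence explains the step.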